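The compounds below may be only part of what the source reports. "The series", "measured", "known", "first", "only" and "open" are said of these compounds alone.

Measured so far:
Compound 1, `CCN(CC)Cc1cccc(Nc2nc3ccccc3n2Cc2ccc(C(F)(F)F)cc2)c1O`, gives > 50000 nM in an ADME assay on CHO cells (Cricetulus griseus) for inhibition, read by MTT assay (on this read-out higher numbers stand for weaker inhibition and lower numbers for stronger inhibition), which is a limit of the assay and not a number.
Compound 2, `Cc1cc(CN)c(O)c(Nc2nc3ccccc3n2Cc2ccc(C(F)(F)F)cc2)c1`, gives 47600 nM in this assay.

Within the data shown here, compound 2 therefore stands as the only compound with a number here; the other value is a limit, as the limit of > 50000 nM in this assay, at which 1 of the 2 values shown sits, shows. Compound 3, `CCN(CC)Cc1cc(C)cc(Nc2nc3ccccc3n2Cc2ccc(C(F)(F)F)cc2)c1O`, differs from compound 2 by diethylamino in place of amino on a saturated chain carbon bound to an aromatic carbon. Among the measured compounds shown here, no two measured compounds differ in one place, so the size of this step cannot be read directly from the numbers. Compound 1, which also carries the (diethylamino)methyl group, reaches only the limit in this assay. The step of a 1.1-fold higher number from compound 2 to compound 3 (0.02 log units; within the scatter) is expected to be small, within the usual scatter or a slight weakening, so that compound 3 stays near the edge of what this assay can report. Compound 3 is estimated at 50000 nM, between 25000 nM and 100000 nM.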

Compound 3, half-maximal inhibitory concentration: 29300 nM
Compound 3: the middle estimate sits 1.7-fold (0.23 log units) above what was measured, and the stated range covers the measured number.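

With a measured partner now on both sides of this position, the change from amino to diethylamino can be read in this assay as a 1.6-fold lower number from compound 2 to compound 3 (0.21 log units; within the scatter), so the much larger group leaves compound 3 indistinguishable from compound 2 here. Methyl in place of hydrogen on an aromatic carbon can also be read for the first time, as an at least 1.7-fold lower number from compound 1 to compound 3 (0.23 log units; that floor lies within the scatter), and that size is only a floor. It is only a floor because compound 1 stands at a limit of the assay and not at a number: the limit of > 50000 nM in this assay, at which 1 of the 3 values shown sits.

The compounds shown leave open whether a morpholine in place of diethylamino, or a chlorine in place of methyl, would separate from compound 3 by more than the scatter. Going by these compounds, they also leave open how far compound 1 lies past its limit, so the full size of the methyl step remains unknown.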